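Sulfamoyl in place of hydroxymethyl in compound 1

This account rests on a few compounds, and the source may have more. Where it says the series, first, only, none or still open, it means among the compounds named here.

Compound 1 `Cc1cc(CCC#N)cc(C)c1Oc1cc(Nc2ccc(C#N)cc2)c(N)cc1CO`: > 23800 nM, a limit
Compound 2 `Cc1cc(/C=C/C#N)cc(C)c1Oc1cc(Nc2ccc(C#N)cc2)c(N)cc1CO`: 16300 nM

In an ADME assay on TZM cells (Homo sapiens) for cytotoxicity, read by XTT assay, with a stated time of 4 days (a lower number here means that less compound is tolerated, a higher number that more compound is tolerated), compound 1 has only a limit and no number, namely (the limit of > 23800 nM in this assay, at which 1 of the 2 values shown sits). Compound 3 `Cc1cc(CCC#N)cc(C)c1Oc1cc(Nc2ccc(C#N)cc2)c(N)cc1S(N)(=O)=O` keeps the core of compound 1 and alters one group: sulfamoyl in place of hydroxymethyl on an aromatic carbon. Thus sulfamoyl stands in place of hydroxymethyl on an aromatic carbon, para to a (4-cyanophenyl)amino group.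

Within the data shown here, only one measured step starts from compound 1, and it bears on this change only indirectly. That step, an at least 1.4-fold lower number from compound 1 to compound 2 (0.16 log units; that floor lies within the scatter), alters the 2-cyanoethyl group, which compound 3 retains. Among the measured compounds shown here, no measured step touches the hydroxymethyl group. For the measured compounds named here, with an at least 1.4-fold lower number from compound 1 to compound 2 (0.16 log units; that floor lies within the scatter) as the sole guide, no step clearly beyond the scatter is expected in this assay, and any shift is expected toward a lower number. The estimated step is an at least 1.1-fold lower number from compound 1 to compound 3 (0.07 log units; that floor lies within the scatter). The assay may again report only a limit for this compound. For compound 3 the expected value is 20000 nM, with an estimated range of 8000 nM to 40000 nM.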

Compound 3, half-maximal cytotoxic concentration: 11100 nM
Compound 3: the middle estimate sits 1.8-fold (0.26 log units) above what was measured; measured number inside the range.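

In this assay, sulfamoyl in place of hydroxymethyl, on the aromatic carbon para to a (4-cyanophenyl)amino group, gives an at least 2.1-fold lower number from compound 1 to compound 3 (0.33 log units; beyond the scatter). This is the first step among the compounds shown that lies beyond the scatter, and it comes at a position that the only earlier step, an at least 1.4-fold lower number from compound 1 to compound 2 (0.16 log units; that floor lies within the scatter), left untouched, as that step altered the 2-cyanoethyl group. Going by these compounds, the new step can be stated only as a floor, and its full size stays unknown, because compound 1 has a limit and no number: the limit of > 23800 nM in this assay, at which 1 of the 3 values shown sits.

The compounds shown leave open whether the lower number is particular to sulfamoyl or would also follow from other groups at this position, such as a carboxylic acid, a methyl group or a longer chain ending in an amine. They also leave open whether sulfamoyl would have the same effect with 2-cyanoethenyl in place of 2-cyanoethyl, and what the change means for any read-out other than this assay.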